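Swapping the Sulfonyl Aryl Group: Expected Inhibition of Compound 3

The source may hold more compounds than are shown below. What is called first, only, known or untested is meant among the compounds shown, and "the series" means these compounds.

Compound 1, `CNCc1cc(-c2cccnc2F)n(S(=O)(=O)c2cccnc2)c1`: 96%
Compound 2, `CNCc1cn(S(=O)(=O)c2ccoc2)c(-c2cccnc2F)c1F`: 95%

Of the compounds shown here, two have been measured in a functional assay on the whole organism (strain Jcl:Sprague-Dawley) for inhibition, with Rattus norvegicus as the target, with stated times of 3 min and 3 h, at a dose of 1 mg/kg by the intravenous route; a lower number here means less inhibition, a higher number more inhibition at the dose given (going by the name of the read-out). Compound 1 gives 96%, and compound 2 gives 95%. Compound 2 stands lowest of the two numbers, but its nearest neighbour, compound 1, lies within the scatter, so no order between them can be read from these values.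

Compound 3 `CNCc1cn(S(=O)(=O)c2cccc(C)n2)c(-c2cccnc2F)c1F` has not yet been measured. It differs from compound 2 in a single place: 6-methylpyridin-2-yl in place of furan-3-yl on a sulfonyl sulfur. Going by the values given here, no step between measured compounds is given for this assay, so the size of the change has to be judged from the two values alone. The two measured compounds carry different groups on the sulfonyl sulfur and their numbers lie level with each other, so the step is expected to stay within the scatter, with no clear direction, as a number 5 percentage points lower from compound 2 to compound 3 (within the scatter). For compound 3 the estimated inhibition is 90%, with a range from 70% to 99%.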

Compound 3, a percentage reported as inhibition, in the whole organism at one dose (the size of the read-out at that dose, not a potency): 91%
For compound 3 the middle estimate is 1 percentage points below the measured one, and the stated range covers the measured number.
By their numbers in this assay, from the lowest: compounds 3, 2 and 1 (each within the scatter of the next).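

Going by these compounds alone, compound 2 and compound 3 give the first comparison in which only the group on the sulfonyl sulfur differs: in this assay, placing 6-methylpyridin-2-yl where furan-3-yl stood gives a number 4 percentage points lower from compound 2 to compound 3 (within the scatter) and so no change that can be told from scatter. For this pair, a five-membered aromatic ring with an oxygen and a six-membered aromatic ring with a nitrogen and a methyl group on the sulfonyl sulfur therefore cannot be separated by this read-out. No measurement is available to explain this result.

The compounds shown leave open whether a group without an aromatic ring on the sulfonyl sulfur, such as cyclohexyl or a short alkyl chain, or a pyridine ring carrying a carboxylic acid, would give a step beyond the scatter. From the compounds shown here alone, each number describes a single dose and is not a potency, and how the two groups would compare at a lower dose remains open.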